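Benzyl amide of compound 1: fluoro to hydrogen

The source may hold more compounds than are shown below. What is called first, only, known or untested is meant among the compounds shown, and "the series" means these compounds.

Compound 1 `C=CC1=C(C(=O)NCc2ccccc2F)C(c2ccc(F)cc2)OC1` sits at the limit of a functional assay on A549 cells (Homo sapiens) for cytotoxicity, read by MTT assay, with a stated time of 24 h; a lower number here means a stronger inhibitor, a higher number a weaker inhibitor: compound 1 gives > 100000 nM, which is a limit of the assay and not a number. Compound 3 `C=CC1=C(C(=O)NCc2ccc(OC)c(OC)c2)C(c2ccc(F)cc2)OC1` also returns only a limit, > 100000 nM. Compound 2 `C=CC1=C(C(=O)Nc2ccc(OCC)cc2)C(c2ccc(OC)cc2)OC1` gives a number, 17600 nM. So compound 1 stands with compound 3 at the limit end of the three values shown, as the limit of > 100000 nM in this assay, at which 2 of the 3 values shown sit, records. Compound 4 `C=CC1=C(C(=O)NCc2ccccc2)C(c2ccc(F)cc2)OC1` differs from compound 1 by hydrogen in place of fluoro on an aromatic carbon. Among the compounds with values here, no measured pair isolates this change; with compound 1 already at the limit, no step beyond the scatter is expected, and a step that the limit leaves unreadable from compound 1 to compound 4 is estimated as essentially none. Compound 4 is expected to give 150000 nM, within 50000 nM to 500000 nM, most likely again reported as a limit.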

Compound 4, half-maximal inhibitory concentration: > 100000 nM
Compound 4 was reported as a limit; the forecaster's own chance of this, stated with the estimate: 70%; the middle value is on the limit's open side.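

In this assay compound 4 gives > 100000 nM, a limit and not a number. Compound 1 is also a limit, so no step can be read between compound 1 and compound 4. The compounds shown leave open whether going from 2-fluorobenzyl to benzyl changes the read-out at all.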